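The compounds below may be only part of what the source reports. "The series", "measured", "known", "first", "only" and "open" are said of these compounds alone.

Measured so far in a functional assay on the whole organism (strain albino) for inhibition, with Mus musculus as the target, with stated times of 30 min, 20 min and 5 min, at a dose of 25 mg/kg by the intraperitoneal route; a lower number here means less inhibition, a higher number more inhibition at the dose given (going by the name of the read-out):

compound 1 `O=c1oc2cc(OCCCN3CCCCC3)ccc2s1` — 67.3%
compound 2 `O=c1oc2cc(OCCCN3CCNCC3)ccc2s1` — 68.2%
compound 3 `O=c1oc2cc(OCCCOc3ccc(Cl)cc3)ccc2s1` — 77.9%

Compound 3 holds the highest of the three numbers in this assay. Its nearest neighbour is compound 2, whose number lies lower by an amount within the scatter, so no order between compound 2 and compound 3 can be read from these two values. The furthest is compound 1, whose number lies lower than that of compound 3 by an amount beyond the scatter.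

Within the data shown here, the only measured step that changes one place is a number 0.9 percentage points higher from compound 1 to compound 2 (within the scatter). That step sits on the chain nitrogen side of the series and leaves the aromatic ring untouched, so it does not bear on the change now in view.

Compound 4 `Cc1ccc(OCCCOc2ccc3sc(=O)oc3c2)cc1` differs from compound 3 as follows: methyl in place of chloro on an aromatic carbon. Among the measured compounds shown here, no measured pair alters a substituent on that aromatic ring, so there is no step from which the size of this change can be read. In the absence of a bearing step the expectation is that compound 4 stays close to compound 3, with a step of a number 2.9 percentage points lower from compound 3 to compound 4 (within the scatter) that is expected to remain within the scatter. For compound 4 the estimate in this assay is 75%, expected to fall between 60% and 88%.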

Compound 4, a percentage reported as inhibition, in the whole organism at one dose (the size of the read-out at that dose, not a potency): 77.3%
Estimate against measurement, compound 4: 2.3 percentage points below; the measured number falls inside the stated range.
By their numbers in this assay, from the lowest: compounds 1, 2, 4 and 3 (each within the scatter of the next, the first and the last beyond it).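

Among these compounds, the first measured change on the far aromatic ring is a number 0.6 percentage points lower from compound 3 to compound 4 (within the scatter) in this assay, so this pair gives the series its first reading at that place, para to a large group. At the single dose used, 4-methylphenyl and 4-chlorophenyl cannot be told apart, and the result gives no sign that this swap matters for the read-out. No measurement of any property of these two groups is available to bear on this result.

From the compounds shown here alone, it remains open whether a substituent of a different kind at this place, such as a carboxylic acid, an amine or a methoxy group, would shift the number beyond the scatter, and whether the same substituents would behave alike elsewhere on that ring. Also open, going by these compounds, is whether a longer chain in place of the present one would change the number while the aromatic end is kept as 4-chlorophenyl or 4-methylphenyl, and whether any match seen here would hold at other doses.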